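Methylation of an Aromatic Amine Against Cytotoxicity

The compounds below may be only part of what the source reports. "The series", "measured", "known", "first", "only" and "open" are said of these compounds alone.

Compound 1 `CNc1ccc2sc(-c3c(Cl)nc(N)nc3N[C@@H]3C[C@H](CO)[C@@H](O)[C@H]3O)nc2c1`: 20000 nM
Compound 2 `CN(C)c1ccc2sc(-c3c(Cl)nc(N)nc3N[C@@H]3C[C@H](CO)[C@@H](O)[C@H]3O)nc2c1`: 25000 nM
Compound 3 `Cc1nc(N)nc(N[C@@H]2C[C@H](CO)[C@@H](O)[C@H]2O)c1-c1nc2ccccc2s1`: 4000 nM

In an ADME assay on cells (Homo sapiens) for cytotoxicity, read by polymerase chain reaction, with a stated time of 3 days (a higher number here means that more compound is tolerated, a lower number that less compound is tolerated), compound 1 gives 20000 nM, compound 2 gives 25000 nM and compound 3 gives 4000 nM. The step of a 1.3-fold higher number from compound 1 to compound 2 (0.10 log units; within the scatter) comes from methyl in place of hydrogen on a nitrogen on an aromatic ring. Compound 4 `CNc1nc(C)c(-c2nc3ccccc3s2)c(N[C@@H]2C[C@H](CO)[C@@H](O)[C@H]2O)n1` carries the same kind of change on the core of compound 3, namely (methyl in place of hydrogen on a nitrogen on an aromatic ring); here the nitrogen's other neighbour is an aromatic carbon alone, whereas in compound 1 the neighbours are an aromatic carbon and a saturated chain carbon. How the core of compound 3 differs from the core of compound 1 is not broken down here. Because a 1.3-fold higher number from compound 1 to compound 2 (0.10 log units; within the scatter) lies within the scatter, compound 4 is expected to show a step of a 1.3-fold higher number from compound 3 to compound 4 (0.10 log units; within the scatter) of like size. Compound 4 is therefore estimated at 5000 nM, most likely between 2000 nM and 12000 nM.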

Compound 4, half-maximal cytotoxic concentration: > 25000 nM
Compound 4: only a limit was reported; the forecaster's own chance of this, stated with the estimate: 5%; middle value at least 5.0-fold (0.69 log units) from the limit.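

In this assay, methyl in place of hydrogen on a nitrogen on an aromatic ring gives an at least 6.2-fold higher number from compound 3 to compound 4 (0.79 log units; beyond the scatter), so the change does not carry over at one size from the core of compound 1 to the core of compound 3: the same change on two cores in this assay, a 1.3-fold higher number (0.10 log units; within the scatter) from compound 1 to compound 2 and an at least 6.2-fold higher number (0.79 log units; beyond the scatter) from compound 3 to compound 4, at least 5.0-fold (0.69 log units) apart, beyond the scatter of two such steps

For compound 4 the assay gives only a limit, > 25000 nM, so the full size of the step stays unknown: the limit of > 25000 nM in this assay, at which 1 of the 4 values shown sits.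

The pairs do not show whether the core or the nitrogen's other neighbours, an aromatic carbon alone in compound 3 and an aromatic carbon and a saturated chain carbon in compound 1, set the gap.

The compounds shown leave open whether an ethyl group or a longer chain on that nitrogen would give a like step. They also leave open how the same amino to methylamino change would read on the core of compound 1.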